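The source may hold more compounds than are shown below. What is called first, only, known or untested is meant among the compounds shown, and "the series" means these compounds.

Within the data shown here, compound 1 `Cc1nc(C(=O)Nc2ccc(Cl)c(-c3nnc4c(Cl)cccn34)c2)cs1` is the only member of this small set that returns an actual number in a functional assay on U-251 cells (Homo sapiens) for antiproliferative activity, read by MTT assay, with a stated time of 72 h (a lower number here means a stronger inhibitor, a higher number a weaker inhibitor), where compound 1 gives 74300 nM. Compound 2 `O=C(Nc1ccc(Cl)c(-c2nnc3c(Cl)cccn23)c1)c1ccc(C(F)(F)F)cc1F` reaches only a limit of the assay: in this assay compound 2 gives > 100000 nM. Compound 3 `CS(=O)(=O)c1ccc(C(=O)Nc2ccc(Cl)c(-c3nnc4c(Cl)cccn34)c2)cc1` likewise reaches only a limit, and in this assay compound 3 gives > 100000 nM. Compound 4 `O=C(Nc1ccc(Cl)c(-c2nnc3c(Cl)cccn23)c1)c1ccc(Cl)cc1Cl` differs from compound 1 by 2,4-dichlorophenyl in place of 2-methyl-1,3-thiazol-4-yl on a carbonyl carbon. Among the measured compounds shown here, the one measured step that alters the same position is an at least 1.3-fold higher number from compound 1 to compound 3 (0.12 log units; that floor lies within the scatter), and its true size cannot be fixed because of the limit of > 100000 nM in this assay, at which 2 of the 3 values shown sit. Compound 2, which also carries a six-membered aromatic ring of carbon only on the carbonyl carbon, adds no number of its own. Both compounds with such a ring there sit at the edge of what this assay can resolve, so the 2,4-dichlorophenyl of compound 4 is expected to behave in the same way, producing a step of a 1.5-fold higher number from compound 1 to compound 4 (0.17 log units; within the scatter) that points toward weaker inhibition, if a number is obtained at all. For compound 4 the expected value in this assay is therefore 110000 nM, within a range from 40000 nM to 300000 nM, with a substantial chance that only a limit is reported.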

Compound 4, half-maximal inhibitory concentration: > 100000 nM
Compound 4: no number, only a limit (the forecaster's own chance of this, stated with the estimate: 60%); the middle value lies beyond the limit too.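

As far as these compounds go, compound 4 stops at a limit of the assay, and the change gives an at least 1.3-fold higher number from compound 1 to compound 4 (0.12 log units; that floor lies within the scatter), so the true size of the step stays unknown and nothing printed sets it beyond the scatter. Among these compounds, the new point is that 2,4-dichlorophenyl, with no substituent shared with the groups of compound 2 or compound 3, ends in the same place: all three compounds with a six-membered aromatic ring of carbon only on the carbonyl carbon stand at the limit in this assay, whereas compound 1, with its five-membered aromatic ring, is the only one to return a number. The step from compound 3 to compound 4 cannot be read, and no order among compound 2, compound 3 and compound 4 can be given, because all three stand at the same edge: the limit of > 100000 nM in this assay, at which 3 of the 4 values shown sit.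

From the compounds shown here alone, it stays open whether the value of compound 1, 74300 nM, depends on the 2-methyl-1,3-thiazol-4-yl as a whole or on its methyl. Going by these compounds, how far past the limit compound 2, compound 3 and compound 4 lie also stays open. Also open, on these data alone, is how an amine or a longer alkyl chain on the carbonyl carbon would read in this assay.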